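This account rests on a few compounds, and the source may have more. Where it says the series, first, only, none or still open, it means among the compounds named here.

For the measured compounds named here, compound 2, `Cn1ncnc1S(=O)(=O)N1CCC(CNC(=O)c2ccc(Cl)cc2Cl)(CC2CC2)CC1`, is the weaker of the two measured members of this small series: in an assay on JAR cells for inhibition of sodium- and chloride-dependent glycine transporter 1 (Homo sapiens), read by scintillation counting, with a stated time of 3 h (a higher number here means a weaker inhibitor, a lower number a stronger inhibitor), compound 2 gives 314 nM, the highest of the two numbers, while compound 1, `Cn1cnnc1S(=O)(=O)N1CCC(CNC(=O)c2ccc(Cl)cc2Cl)(CC2CC2)CC1`, gives 124 nM. Going by the values given here, the one step that bears on the next change is a 2.5-fold higher number from compound 1 to compound 2 (0.40 log units; beyond the scatter), which shows that swapping one methyl-bearing triazole for another on the sulfonyl sulfur moved the number modestly. Compound 3, `CCn1cc(S(=O)(=O)N2CCC(CNC(=O)c3ccc(Cl)cc3Cl)(CC3CC3)CC2)nn1`, carries a further variation at the same place: 1-ethyl-1H-1,2,3-triazol-4-yl in place of 1-methyl-1H-1,2,4-triazol-5-yl on a sulfonyl sulfur. Among the compounds with values here, no measured pair shows this particular ring exchange, so the one modest step from compound 1 to compound 2 is the only guide, and it suggests that another triazole swap is unlikely to move the number far. For compound 3 the expected step of a 1.3-fold lower number from compound 2 to compound 3 (0.10 log units; within the scatter) is therefore within the scatter, and its value in this assay is estimated at 250 nM, in the range from 80 nM to 800 nM.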

Compound 3, half-maximal inhibitory concentration: 28.2 nM
The estimate for compound 3 lay 8.9-fold (0.95 log units) above the measured number; the whole stated range lies above it.
By their numbers in this assay, from the lowest: compound 3; then compound 1; then compound 2.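

The position on the sulfonyl sulfur proves far more sensitive than the first triazole exchange indicated: in this assay, the change to 1-ethyl-1H-1,2,3-triazol-4-yl gives an 11-fold lower number from compound 2 to compound 3 (1.05 log units; beyond the scatter), a large step set against the modest 2.5-fold higher number from compound 1 to compound 2 (0.40 log units; beyond the scatter). The same group also improves on the other methyl triazole, with a 4.4-fold lower number from compound 1 to compound 3 (0.64 log units; beyond the scatter), so compound 3 is the most potent of the three, with both of its steps beyond the scatter. No measured evidence accounts for this gain.

The change alters the triazole ring and its alkyl group at once, so the compounds shown cannot divide the gain between the 1,2,3-triazole and the ethyl group. A 1-methyl-1H-1,2,3-triazol-4-yl group would separate the two, and a propyl chain on the same ring would test whether a longer chain goes further.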